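Chloro on Compound 2: A Small Expected Step

The compounds below may be only part of what the source reports. "The series", "measured", "known", "first", "only" and "open" are said of these compounds alone.

Of the compounds shown here, two have so far been read in a functional assay on NCI-H460 cells (Homo sapiens) for inhibition, read by MTT assay, with a stated time of 24 h, tested at 0.1 ug/mL; a higher number here means more inhibition of growth at the concentration tested, a lower number less inhibition of growth. In this test, compound 1 (`O=C(CCCCC1CCSS1)Nc1ccccc1Cl`) gives 8%, and compound 2 (`O=C(CCCCC(S)CCS)Nc1ccccc1`) gives 5.5%. These two readings lie within the usual scatter of each other, so no order can be drawn between them, and compound 2 stands level with compound 1. Both show little inhibition of growth at the concentration tested.

The next compound, compound 3 (`O=C(CCCCC(S)CCS)Nc1ccccc1Cl`), comes from compound 2 through one structural change: chloro in place of hydrogen on an aromatic carbon. This places chloro in place of hydrogen on an aromatic carbon. For the measured compounds named here, no measured pair shows this change on its own, so the data give no direct size for it in this assay. With only compound 2 at 5.5% and compound 1 at 8% to go on, no step beyond the scatter is expected, and no direction is strongly favoured. The estimated change is a number 1.5 percentage points higher from compound 2 to compound 3 (within the scatter), which would stay within the scatter. Compound 3 is expected to give 7%, with an estimated range from 1% to 17%.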

Compound 3, percent growth inhibition at one concentration: 6.36%
Estimate against measurement, compound 3: 0.6 percentage points above; measured number inside the range.
By their numbers in this assay, from the lowest: compounds 2, 3 and 1 (each within the scatter of the next).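

In this assay, chloro in place of hydrogen on an aromatic carbon, ortho to a large group, now has a directly measured size: a number 0.9 percentage points higher from compound 2 to compound 3 (within the scatter). On this pair of compounds, the chloro therefore leaves the reading within the scatter, and the change gives no sign of opening a difference at this position. Compound 3 also gives a second direct comparison, in which a group of 5 heavy atoms with no ring stands in place of the group with one five-membered non-aromatic ring with 2 hetero atoms, on the saturated chain carbon, and this too gives no separation: a number 1.6 percentage points lower from compound 1 to compound 3 (within the scatter). No independent data bear on either step.

The compounds shown leave open whether a fluoro, a methoxy or an amine on this same aromatic carbon would give a step beyond the scatter. They also leave open whether a longer chain between the carbonyl carbon and the two sulfur atoms would change the reading in this assay, with or without the chloro.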